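The compounds below may be only part of what the source reports. "The series", "measured", "known", "first", "only" and "open" are said of these compounds alone.

Measured compounds in a functional assay on COLO 205 cells (Homo sapiens) for antiproliferative activity, read by MTT assay; a lower number here means a stronger inhibitor, a higher number a weaker inhibitor:

Compound 1, `FC(F)(F)Oc1ccc(-c2cc(CN(c3ncccn3)c3nc4ccccc4s3)on2)cc1`: 5690 nM
Compound 2, `COc1ccc(-c2cc(CN(c3ncccn3)c3nc4ccccc4s3)on2)cc1`: 5040 nM

Going by the values given here, compound 2 gives the lowest of the two numbers so far, yet its nearest neighbour is compound 1, and the step of a 1.1-fold lower number from compound 1 to compound 2 (0.05 log units; within the scatter) lies within the scatter, so the two compounds cannot be told apart on these data. Compound 3, `Fc1ccccc1-c1cc(CN(c2ncccn2)c2nc3ccccc3s2)on1`, is not yet measured. It differs from compound 2 in one place: 2-fluorophenyl in place of 4-methoxyphenyl on an aromatic carbon. Among the compounds with values here, only one measured step bears on this change, the one from compound 1 to compound 2, which also swaps the group carried on this phenyl ring, and that step was a 1.1-fold lower number from compound 1 to compound 2 (0.05 log units; within the scatter). That single step gives no sign that changes on this ring move the number beyond the scatter, though the present change replaces the whole ring substituent pattern rather than a single group on it, so the expectation is held loosely. In this assay the step of a 1.1-fold higher number from compound 2 to compound 3 (0.04 log units; within the scatter) is expected, that is, no movement beyond the scatter. Compound 3 is therefore estimated at 5500 nM, in a range from 1800 nM to 17000 nM.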

Compound 3, half-maximal inhibitory concentration: 13200 nM
The estimate for compound 3 lay 2.4-fold (0.38 log units) below the measured number; the range from low to high includes it.
By their numbers in this assay, from the lowest: compounds 2 and 1 (each within the scatter of the next); then compound 3.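

In this assay, replacing 4-methoxyphenyl with 2-fluorophenyl on the aromatic carbon next to the ring nitrogen gives a 2.6-fold higher number from compound 2 to compound 3 (0.42 log units; beyond the scatter) and replacing 4-(trifluoromethoxy)phenyl with the same group gives a 2.3-fold higher number from compound 1 to compound 3 (0.37 log units; beyond the scatter) in the second comparison. These two steps show that a change at this position can move the number beyond the scatter, something the step between compound 1 and compound 2 could not show, and here the change makes compound 3 the weakest inhibitor of the three, though only modestly. No measurement shown here accounts for this loss of activity.

Compound 3 differs from the other two compounds both in the atom carried on the phenyl ring and in where that ring carries it, so these data cannot separate the effect of the fluorine from the effect of its location. Going by these compounds, a 4-fluorophenyl, a 2-methoxyphenyl or a plain phenyl group would help pull those two changes apart, and the rest of the shared core stays the same in all three compounds, so its contribution remains open.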